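A few compounds are considered here, and "the series" means these few. Any claim that something is new, unique, unknown or untested is made for them only; others in the source may bear on it.

Compound 1 (`Cn1ncc(Cl)c1-c1cc(C(=O)N[C@@H]2CN[C@H](CCNS(C)(=O)=O)C[C@H]2c2ccc(F)c(F)c2)oc1Cl`): 1530 nM
Compound 2 (`Cn1ncc(Cl)c1-c1cc(C(=O)N[C@@H]2CN[C@H](CC(O)CO)C[C@H]2c2ccc(F)c(F)c2)oc1Cl`): 690 nM
Compound 3 (`Cn1ncc(Cl)c1-c1cc(C(=O)N[C@@H]2CN[C@H](CCO)C[C@H]2c2ccc(F)c(F)c2)oc1Cl`): not yet measured

In a functional assay on OVCAR-8 cells (Homo sapiens) for antiproliferative activity (on this read-out lower numbers stand for stronger inhibition and higher numbers for weaker inhibition), compound 2 holds the lower of the two numbers (690 nM) and compound 1 holds the higher (1530 nM). Compound 3 differs from compound 2 by hydrogen in place of hydroxymethyl on a saturated chain carbon bound to an oxygen on a saturated carbon and a saturated chain carbon and the change reads as hydrogen in place of hydroxymethyl on a saturated chain carbon bound to an oxygen on a saturated carbon and a saturated chain carbon, or 2,3-dihydroxypropyl to 2-hydroxyethyl. Going by the values given here, only one measured step touches this chain (a 2.2-fold lower number from compound 1 to compound 2 (0.35 log units; beyond the scatter)). It is modest and a different group leaves in it, so it is a loose guide. In this assay a step of no greater size is therefore expected, most likely none beyond the scatter, with a slight lean to a higher number. The expected step is small (a 1.2-fold higher number from compound 2 to compound 3 (0.06 log units; within the scatter)). Compound 3 is estimated at 800 nM (expected range 300 nM to 2000 nM).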

Compound 3, half-maximal inhibitory concentration: 460 nM
Compound 3: the middle estimate sits 1.7-fold (0.24 log units) above what was measured; measured number inside the range.
By their numbers in this assay, from the lowest: compounds 3 and 2 (each within the scatter of the next); then compound 1.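

In this assay, 2-hydroxyethyl in place of 2,3-dihydroxypropyl gives a 1.5-fold lower number from compound 2 to compound 3 (0.18 log units; within the scatter), so the hydroxymethyl that leaves is not required to keep the number in this range at this position. Hydroxy in place of methanesulfonamido gives a 3.3-fold lower number from compound 1 to compound 3 (0.52 log units; beyond the scatter), which means that compound 1 now stands apart from both hydroxy-bearing chains, compound 2 and compound 3, and these two cannot be told apart. Nothing available explains either step.

On these data alone, what remains open is whether the hydroxy itself matters, since a plain ethyl group at this position would be needed to separate its contribution from that of the chain. As far as these compounds go, it is also open how an amine or a carboxylic acid at the end of this chain would read in this assay.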